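The compounds below may be only part of what the source reports. "The series", "measured", "known", "first", "only" and "open" are said of these compounds alone.

In a functional assay on SW480 cells (Homo sapiens) for cytotoxicity, read by MTT assay, with a stated time of 4 days (a higher number here means a weaker inhibitor, a lower number a stronger inhibitor), compound 1 `C=C1C(=O)[C@]23C[C@@]1(O)CC[C@H]2c1ccc(O)c(C)c1[C@@H]3Cn1cc(-c2ccc(F)cc2)nn1` gives 250 nM. Compound 2 `C=C1C(=O)[C@]23C[C@@]1(O)CC[C@H]2c1ccc(O)c(C)c1[C@@H]3Cn1cc(-c2ccc(C)cc2)nn1` differs from it by methyl in place of fluoro on an aromatic carbon, and in this assay compound 2 gives 330 nM, a step of a 1.3-fold higher number from compound 1 to compound 2 (0.12 log units; within the scatter). Compound 3 `C=C1C(=O)[C@]23C[C@@]1(O)CC[C@H]2c1ccc(OS(=O)(=O)c2ccc(C)cc2)c(C)c1[C@@H]3Cn1cc(-c2ccc(F)cc2)nn1` has a different core, differing from compound 1 by (4-methylphenyl)sulfonyl in place of hydrogen on an oxygen on an aromatic ring; in this assay compound 3 gives 1630 nM, a step of a 6.5-fold higher number from compound 1 to compound 3 (0.81 log units; beyond the scatter). Compound 4 `C=C1C(=O)[C@]23C[C@@]1(O)CC[C@H]2c1ccc(OS(=O)(=O)c2ccc(C)cc2)c(C)c1[C@@H]3Cn1cc(-c2ccc(C)cc2)nn1` has not yet been measured. It differs from compound 3 by methyl in place of fluoro on an aromatic carbon, the same change as between compound 1 and compound 2, at a place described in the same words. Because the earlier step was a 1.3-fold higher number from compound 1 to compound 2 (0.12 log units; within the scatter), compound 4 is expected to show a step of a 1.3-fold higher number from compound 3 to compound 4 (0.11 log units; within the scatter). In this assay compound 4 is estimated at 2100 nM, expected between 1000 nM and 4500 nM.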

Compound 4, half-maximal inhibitory concentration: 1460 nM
Compound 4: the middle estimate sits 1.4-fold (0.16 log units) above what was measured; the measured number falls inside the stated range.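

In this assay, methyl in place of fluoro gives a 1.1-fold lower number from compound 3 to compound 4 (0.05 log units; within the scatter), so this swap leaves the number within the scatter on both cores: the same change on two cores in this assay, a 1.3-fold higher number (0.12 log units; within the scatter) from compound 1 to compound 2 and a 1.1-fold lower number (0.05 log units; within the scatter) from compound 3 to compound 4, 1.5-fold (0.17 log units) apart, within the scatter of two such steps. Placing (4-methylphenyl)sulfonyl on the oxygen gives a 4.4-fold higher number from compound 2 to compound 4 (0.65 log units; beyond the scatter), a rise beyond the scatter that carries over with a similar size whichever of the two groups is present: the same change on two cores in this assay, a 6.5-fold higher number (0.81 log units; beyond the scatter) from compound 1 to compound 3 and a 4.4-fold higher number (0.65 log units; beyond the scatter) from compound 2 to compound 4, 1.5-fold (0.17 log units) apart, within the scatter of two such steps. In these four compounds the two changes therefore behave as if independent, but this rests on one pair of steps for each change and does not show why the numbers move or that the pattern extends to other groups.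

The compounds shown leave open whether an amine or a carboxylic acid in place of the methyl or fluoro would carry over between cores in the same way. They also leave open how a simple acetyl group on that oxygen would compare with (4-methylphenyl)sulfonyl.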